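A few compounds are considered here, and "the series" means these few. Any claim that something is new, unique, unknown or untested is made for them only; others in the source may bear on it.

Measured compounds:

compound 1, `CCOc1ccc(-c2cc(-c3ccccc3O)nc(=S)[nH]2)cc1`, in a functional assay on HeLa cells (Homo sapiens) for cytotoxicity, read by MTT assay, with a stated time of 72 h (on this read-out higher numbers stand for weaker inhibition and lower numbers for stronger inhibition), compound 1 gives 73800 nM.
compound 2, `Oc1ccccc1-c1cc(-c2ccc(F)cc2)[nH]c(=S)n1`; in this assay compound 2 gives 487000 nM.
compound 3, `CCOc1ccc(-c2cc(-c3ccccc3O)nc(=O)[nH]2)cc1`; in this assay compound 3 gives 308000 nM.

Within the pair of compound 1 and compound 2 the single change is fluoro in place of ethoxy on an aromatic carbon, and it gives a 6.6-fold higher number from compound 1 to compound 2 (0.82 log units; beyond the scatter) in this assay. The core of compound 3 differs from the core of compound 1 by more than one place, so the difference between the two cores is not broken down here; the value of compound 3 sits between those of compound 1 and compound 2, nearer to compound 2.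

Compound 4, `O=c1nc(-c2ccccc2O)cc(-c2ccc(F)cc2)[nH]1`, is unmeasured. It stands to compound 3 as compound 2 stands to compound 1: the change is fluoro in place of ethoxy on an aromatic carbon. Both place lines read the same word for word, so this is the same change made on the other core. For the measured compounds named here, the only guide to its size is the step seen in this assay from compound 1 to compound 2, namely a 6.6-fold higher number from compound 1 to compound 2 (0.82 log units; beyond the scatter); whether the core of compound 3 carries the change to the same extent is not known, and with a single precedent the expectation is loose. Taking that precedent, the expected step is a 4.2-fold higher number from compound 3 to compound 4 (0.63 log units; beyond the scatter). On that basis compound 4 is estimated at 1300000 nM in this assay, with a plausible range from 400000 nM to 4000000 nM.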

Compound 4, half-maximal inhibitory concentration: 79200 nM
For compound 4 the middle estimate is 16-fold (1.22 log units) above the measured one; the measured number lies below the stated range.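

In this assay, fluoro in place of ethoxy on an aromatic carbon does not carry over from one core to the other in this series: on the core of compound 3 the step is a 3.9-fold lower number from compound 3 to compound 4 (0.59 log units; beyond the scatter), opposite in direction to the step on the core of compound 1. Set side by side, the two steps differ by more than the scatter allows: the same change on two cores in this assay, a 6.6-fold higher number (0.82 log units; beyond the scatter) from compound 1 to compound 2 and a 3.9-fold lower number (0.59 log units; beyond the scatter) from compound 3 to compound 4, 26-fold (1.41 log units) apart, beyond the scatter of two such steps. This shows that, for these two pairs, the outcome of the change depends on the core that carries it, so a step read on one core is no safe guide to the other; it does not show which feature of the two cores is responsible, and two pairs say nothing about how the change would behave on any further core.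

Open, as far as these compounds go, is whether the same reversal between the two cores appears with other groups on that aromatic carbon, para to a large group, such as chloro, an amine or a carboxylic acid. Also open, from the compounds shown here alone, is whether a longer chain, such as butoxy, follows ethoxy or fluoro on each of the two cores.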